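This account rests on a few compounds, and the source may have more. Where it says the series, first, only, none or still open, it means among the compounds named here.

Measured in an ADME assay on microsomes from liver (Homo sapiens) for metabolic stability; on this read-out lower numbers stand for slow clearance and higher numbers for fast clearance:
Compound 1 `CC(=O)N[C@@H]1CCC[C@H](C(=O)Nc2cc(-c3cnn4c3CCCC4)c(Cl)cn2)C1`: 17 mL.min-1.g-1
Compound 2 `CC(=O)N[C@@H]1CCC[C@H](C(=O)Nc2cc(-c3cnn4c3NCCC4)c(Cl)cn2)C1`: 6.2 mL.min-1.g-1

Compound 2 has the lower of these two numbers, at 6.2 mL.min-1.g-1. Compound 3 `CC(=O)N[C@@H]1CCC[C@H](C(=O)Nc2cc(-c3cnc4n3CC(C)(C)C4)c(Cl)cn2)C1` differs from it in one place: a group of 10 heavy atoms (8 carbon, 2 nitrogen; one five-membered non-aromatic ring with 1 hetero atom, one five-membered aromatic ring with 2 hetero atoms) in place of a group of 9 heavy atoms (6 carbon, 3 nitrogen; one five-membered aromatic ring with 2 hetero atoms, one six-membered non-aromatic ring with 2 hetero atoms), on an aromatic carbon. Among the compounds with values here, only one measured step bears on this change: a 2.7-fold lower number from compound 1 to compound 2 (0.44 log units; beyond the scatter). Like the group in compound 1, the entering group carries fewer nitrogens than the group in compound 2, so a move back up of similar size is expected in this assay. One step is thin evidence, however, and the new ring system has not been tested. The expected move is a 2.1-fold higher number from compound 2 to compound 3 (0.32 log units; beyond the scatter). The estimate for compound 3 is 13 mL.min-1.g-1, with a range of 5 mL.min-1.g-1 to 35 mL.min-1.g-1.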

Compound 3, intrinsic clearance in microsomes in the Homo sapiens assay: 63 mL.min-1.g-1
Beside the measured number, compound 3's estimate is 4.8-fold (0.69 log units) below it, outside the stated range (above it).
By their numbers in the Homo sapiens assay, from the lowest: compound 2; then compound 1; then compound 3.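

In the Homo sapiens assay, the group opposite the ring nitrogen moves the number much further than the earlier pair showed, with a 10-fold higher number from compound 2 to compound 3 (1.01 log units; beyond the scatter) and with a 3.7-fold higher number from compound 1 to compound 3 (0.57 log units; beyond the scatter) as well. The entering group therefore does more than undo the gain seen with compound 2. In a physicochemical assay for lipophilicity, using the shake flask method, measured as octanol-water partition, at pH 7.4 (on this read-out higher numbers stand for higher lipophilicity and lower numbers for lower lipophilicity), compound 2 gives 2.4 and compound 3 gives 3.6. This rise in clearance goes along with a rise in lipophilicity in the physicochemical assay: the measured distribution coefficient of compound 2, 2.4, and of compound 3, 3.6, a number 1.20 log units higher (beyond the scatter). As far as these compounds go, whether the rise follows the ring itself or its dimethyl substitution stays open, as does the effect of a hydroxyl group or an amine on that five-membered non-aromatic ring.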